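This account rests on a few compounds, and the source may have more. Where it says the series, first, only, none or still open, it means among the compounds named here.

Measured in a functional assay on PC-3 cells (Homo sapiens) for cytotoxicity, read by MTT assay, with a stated time of 72 h; a lower number here means a stronger inhibitor, a higher number a weaker inhibitor:
- compound 1 `CNC(=O)c1cc(Oc2ccc(NC(=O)c3cc(-c4ccc(Cl)cc4)ncn3)cc2F)ccn1`: > 100000 nM (a limit)
- compound 2 `CCc1ccc(-c2cc(C(=O)Nc3ccc(Oc4ccnc(C(=O)NC)c4)c(F)c3)ncn2)cc1`: 15600 nM
- compound 3 `CNC(=O)c1cc(Oc2ccc(NC(=O)c3cc(-c4ccccc4)ncn3)cc2F)ccn1`: 44300 nM

Compound 3 holds the higher of the two actual numbers, with compound 2 nearest. Compound 1 stands at the limit > 100000 nM.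

Compound 4 `CNC(=O)c1cc(Oc2ccc(NC(=O)c3cc(-c4ccc(OC)cc4)ncn3)cc2F)ccn1` has methoxy in place of hydrogen on an aromatic carbon, para to a large group (methoxy in place of hydrogen on an aromatic carbon).

For the measured compounds named here, two measured steps bear on this: a 2.8-fold higher number from compound 2 to compound 3 (0.45 log units; beyond the scatter), and an at least 2.2-fold lower number from compound 1 to compound 3 (0.35 log units; beyond the scatter). They run in opposite directions, so the direction for methoxy is uncertain. Compound 2, at 15600 nM, gives only a slight lean towards a lower number.

The expected change is modest: a 1.5-fold lower number from compound 3 to compound 4 (0.17 log units; within the scatter). Compound 4 is estimated at 30000 nM, within a range of 10000 nM to 90000 nM.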

Compound 4, half-maximal inhibitory concentration: 56200 nM
For compound 4 the middle estimate is 1.9-fold (0.27 log units) below the measured one, and the stated range covers the measured number.
By their numbers in this assay, from the lowest: compound 2; then compounds 3 and 4 (each within the scatter of the next). At a limit, above all of these: compound 1.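

In this assay, methoxy para to a large group does not separate from hydrogen: a 1.3-fold higher number from compound 3 to compound 4 (0.10 log units; within the scatter). Methoxy stays clearly apart from ethyl, a 3.6-fold higher number from compound 2 to compound 4 (0.56 log units; beyond the scatter), so it does not carry the lower number seen with ethyl. Chloro to methoxy shows an at least 1.7-fold lower number from compound 1 to compound 4 (0.25 log units; that floor lies within the scatter), which is no firm gap, and compound 1 stands at a limit: the limit of > 100000 nM in this assay, at which 1 of the 4 values shown sits.

From the compounds shown here alone, how an amine or a longer chain such as propyl at this position compares with ethyl stays open. Going by these compounds, the true distance of chloro from the other groups also stays open.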